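Replacing the Azide on a Sulfonyl Sulfur with an Anilide

The source may report more compounds than this note shows. Statements on the series, on what has been measured and on what is new or still open speak of the compounds shown alone.

Of the compounds shown here, three sharing one core have been measured in a functional assay with Rattus norvegicus as the target; a higher number here means that more compound is needed for the effect, a lower number that less compound is needed. Compound 1, `CC1(C)C=C(n2ccccc2=O)c2cc(S(=O)(=O)N=[N+]=[N-])ccc2O1`, gives 204 nM, the lowest of the three numbers. Compound 2, `CC1(C)C=C(n2ccccc2=O)c2cc(S(N)(=O)=O)ccc2O1`, gives 224 nM, and the step of a 1.1-fold higher number from compound 1 to compound 2 (0.04 log units; within the scatter) lies within the scatter. Compound 3, `CC(C)NS(=O)(=O)c1ccc2c(c1)C(n1ccccc1=O)=CC(C)(C)O2`, gives 1950 nM; the step of a 9.6-fold higher number from compound 1 to compound 3 (0.98 log units; beyond the scatter) and the step of an 8.7-fold higher number from compound 2 to compound 3 (0.94 log units; beyond the scatter) both lie beyond the scatter.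

Compound 4, `CC1(C)C=C(n2ccccc2=O)c2cc(S(=O)(=O)Nc3ccc(C#N)cc3)ccc2O1`, has not been measured. It differs from compound 1 in one place: (4-cyanophenyl)amino in place of azido on a sulfonyl sulfur. Two of the measured steps bear on this change. Exchanging the azido for a plain amino left the number essentially unchanged, as the step of a 1.1-fold higher number from compound 1 to compound 2 (0.04 log units; within the scatter) shows, whereas putting an isopropyl on the sulfonamide nitrogen raised the number, as the step of an 8.7-fold higher number from compound 2 to compound 3 (0.94 log units; beyond the scatter) shows. Compound 4 also carries a substituent on that nitrogen, a different one, so a higher number than for compound 1 is expected, of roughly the size seen for compound 3, though a single example gives little ground for the exact size. Compound 4 is therefore expected to give 1500 nM in this assay, within the range 400 nM to 6000 nM. The expected step is a 7.4-fold higher number from compound 1 to compound 4 (0.87 log units; beyond the scatter).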

Compound 4, half-maximal effective concentration: 1380 nM
Estimate against measurement, compound 4: 1.1-fold (0.04 log units) above; the range from low to high includes it.
By their numbers in this assay, from the lowest: compounds 1 and 2 (each within the scatter of the next); then compounds 4 and 3 (each within the scatter of the next).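

Compound 4 adds a second, quite different substituent on the sulfonamide nitrogen, and the rise seen with isopropyl appears again in this assay, with a 6.2-fold higher number from compound 2 to compound 4 (0.79 log units; beyond the scatter) for the 4-cyanophenyl group. Exchanging one substituent for the other gives a 1.4-fold lower number from compound 3 to compound 4 (0.15 log units; within the scatter), so this assay does not separate them, even though the 4-cyanophenyl group brings a six-membered aromatic ring and a triple bond that isopropyl lacks. Measured against the azide, the change gives a 6.8-fold higher number from compound 1 to compound 4 (0.83 log units; beyond the scatter), so among these four compounds the two with a carbon group on the sulfonamide nitrogen, compound 3 and compound 4, both have higher numbers than compound 1 and compound 2, and no compound shown goes against this.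

Nothing available here explains why a group on that nitrogen raises the number. From the compounds shown here alone, it remains open whether a methyl, a plain phenyl without the nitrile, or a chain ending in an amine on the same nitrogen would stay near compound 2 or rise as far as compound 3 and compound 4.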